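Bromo added to the aryl urea of compound 1

This account rests on a few compounds, and the source may have more. Where it says the series, first, only, none or still open, it means among the compounds named here.

The series shares a diaryl ether urea core; compound 1 `O=C(Nc1ccc(Oc2ccc(-c3nccs3)cc2)cc1)Nc1cccc(C(F)(F)F)c1` is one of three compounds tested in a functional assay on MDA-MB-231 cells (Homo sapiens) for inhibition, read by MTT assay and WST assay, with a stated time of 72 h, tested at 10 uM (on this read-out lower numbers stand for less inhibition of growth and higher numbers for more inhibition of growth at the one concentration tested), where compound 1 gives 64.1%. Compound 2 `O=C(Nc1ccc(Oc2ccc(-c3nccs3)cc2)cc1)Nc1ccc(F)c(C(F)(F)F)c1` gives 71.8%, and compound 3 `Cc1ccc(NC(=O)Nc2ccc(Oc3ccc(-c4nccs4)cc3)cc2)cc1` gives 22.8%. The step of a number 7.7 percentage points higher from compound 1 to compound 2 (within the scatter) stays within the scatter, whereas the step of a number 41.3 percentage points lower from compound 1 to compound 3 (beyond the scatter) is large. Compound 4 `O=C(Nc1ccc(Oc2ccc(-c3nccs3)cc2)cc1)Nc1cc(Br)cc(C(F)(F)F)c1` differs from compound 1 by bromo in place of hydrogen on an aromatic carbon, on the aromatic carbon meta to a trifluoromethyl group. Among the measured compounds shown here, the only step that bears on this change, the addition of a halogen to the same ring from compound 1 to compound 2, was within the scatter, so in this assay no step beyond the scatter is expected for compound 4, which is estimated at 67% (range 50% to 82%), a step of a number 2.9 percentage points higher from compound 1 to compound 4 (within the scatter).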

Compound 4, percent growth inhibition at one concentration: 72.8%
Beside the measured number, compound 4's estimate is 5.8 percentage points below it; measured number inside the range.
By their numbers in this assay, from the lowest: compound 3; then compounds 1, 2 and 4 (each within the scatter of the next).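

In this assay, a bromo on the aromatic carbon meta to a trifluoromethyl group is tolerated, with a number 8.7 percentage points higher from compound 1 to compound 4 (within the scatter) and a number 1 percentage points higher from compound 2 to compound 4 (within the scatter) both printed as within the scatter. The 3-bromo-5-(trifluoromethyl)phenyl and 4-fluoro-3-(trifluoromethyl)phenyl groups therefore cannot be told apart here. The a number 50 percentage points higher from compound 3 to compound 4 (beyond the scatter) is large and sets compound 3 apart from compound 4.

From the compounds shown here alone, whether the trifluoromethyl group is needed remains open, as does the outcome of an amine or a carboxylic acid in place of the bromo. No evidence is available to explain these steps.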